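The source may hold more compounds than are shown below. What is called first, only, known or untested is meant among the compounds shown, and "the series" means these compounds.

Measured so far in an assay on COS-7 cells for agonist activity at Free fatty acid receptor 1 (Homo sapiens), read by scintillation counting and inositol phosphate accumulation, with a stated time of 90 min; a higher number here means that more compound is needed for the effect, a lower number that less compound is needed:
compound 1, `Cc1cc(=O)oc2cc(OCc3nc(N)nc(Nc4ccc(Cl)cc4)n3)ccc12`: 32500 nM
compound 2, `Cc1ccc(Nc2nc(N)nc(COc3ccc4c(C)cc(=O)oc4c3)n2)cc1`: 1790 nM
compound 3, `Cc1ccc(Nc2nc(N)nc(COc3ccc4c(C)cc(=O)oc4c3)n2)cc1C`: 210 nM

All three share one core and differ only in the ring attached to the amine. Compound 3 differs from compound 2 by methyl in place of hydrogen on an aromatic carbon, and this gave an 8.5-fold lower number from compound 2 to compound 3 (0.93 log units; beyond the scatter). Compound 1 differs from compound 2 by chloro in place of methyl on an aromatic carbon, which gave an 18-fold higher number from compound 2 to compound 1 (1.26 log units; beyond the scatter), a large loss.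

Compound 4, `Cc1cc(Nc2nc(N)nc(COc3ccc4c(C)cc(=O)oc4c3)n2)ccc1Cl`, has not yet been measured. It differs from compound 3 by chloro in place of methyl on an aromatic carbon. This is the same kind of change as that from compound 2 to compound 1, but the surroundings are not identical: in compound 4 the chloro sits ortho to a methyl group as well as para to a large group, whereas in compound 1 it is only para to a large group. Going by the values given here, the one measured example of this exchange, an 18-fold higher number from compound 2 to compound 1 (1.26 log units; beyond the scatter), points to a weaker compound. The step expected in this assay is a 14-fold higher number from compound 3 to compound 4 (1.15 log units; beyond the scatter), resting on that single earlier step. Compound 4 is therefore expected to give roughly 3000 nM, with a plausible range from 800 nM to 12000 nM.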

Compound 4, half-maximal effective concentration: 240 nM
Beside the measured number, compound 4's estimate is 13-fold (1.10 log units) above it; the measured number lies below the stated range.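

In this assay, the exchange of methyl for chloro that was so damaging on the first pair shows no readable effect on the second, a 1.1-fold higher number from compound 3 to compound 4 (0.06 log units; within the scatter), so its size did not carry over from one core to the other: the same change on two cores in this assay, an 18-fold higher number (1.26 log units; beyond the scatter) from compound 2 to compound 1 and a 1.1-fold higher number (0.06 log units; within the scatter) from compound 3 to compound 4, 16-fold (1.20 log units) apart, beyond the scatter of two such steps. Seen from the other side, adding a methyl helps far more on the chloro compound, a 140-fold lower number from compound 1 to compound 4 (2.13 log units; beyond the scatter), than on the methyl compound, and replacing 4-methylphenyl with 4-chloro-3-methylphenyl also gives a clear gain, a 7.5-fold lower number from compound 2 to compound 4 (0.87 log units; beyond the scatter): the same change on two cores in this assay, an 8.5-fold lower number (0.93 log units; beyond the scatter) from compound 2 to compound 3 and a 140-fold lower number (2.13 log units; beyond the scatter) from compound 1 to compound 4, 16-fold (1.20 log units) apart, beyond the scatter of two such steps. These pairs show that the effect of each change depends on the other group on the ring, but two pairs give no general rule and do not show why this happens.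

The compounds shown leave open whether bromo or methoxy in place of the chloro would behave the same way. They also leave open whether an ethyl in place of the added methyl would give a similar gain.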